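Methoxy to isopropoxy: expected effect on stability

The source may hold more compounds than are shown below. What is called first, only, known or untested is meant among the compounds shown, and "the series" means these compounds.

In an ADME assay on microsomes from liver (Homo sapiens) for metabolic stability, with a stated time of 60 min, tested at 1 uM (a lower number here means that less of the compound is left, a higher number that more of the compound is left), compound 1 `COc1cc(-c2cnn3cc(OC)c(-c4cnn(C)c4)nc23)ccn1` gives 43%, the higher of the two numbers available, while compound 2 `COc1cc(-c2cnn3cc(OC)c(-c4cc(C)no4)nc23)ccn1` gives 31%. Compound 3 `COc1cn2ncc(-c3ccnc(OC(C)C)c3)c2nc1-c1cnn(C)c1` keeps the core of compound 1 and changes one group: isopropyl in place of methyl on an oxygen on an aromatic ring, that is, methoxy to isopropoxy. Within the data shown here, the only measured step is a number 12 percentage points lower from compound 1 to compound 2 (beyond the scatter). It concerns a different place in the molecule, so it bears on this change only indirectly, as a guide to how far a single exchange can move the number. Among the measured compounds shown here, no measured step covers the group on the oxygen, so the direction remains a judgement. The step is expected to be modest and downward, with a number 10 percentage points lower from compound 1 to compound 3 (within the scatter) as the estimate. For compound 3, the expected value in this assay is 33%, with an estimated range from 16% to 50%.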

Compound 3, percent of the compound remaining: 32%
Beside the measured number, compound 3's estimate is 1 percentage points above it; measured number inside the range.
By their numbers in this assay, from the lowest: compounds 2 and 3 (each within the scatter of the next); then compound 1.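

In this assay, among these compounds, the group on the oxygen on the aromatic ring proves to be a place where the number responds: isopropyl in place of methyl gives a number 11 percentage points lower from compound 1 to compound 3 (beyond the scatter), the first measured step at this position. Together with a number 12 percentage points lower from compound 1 to compound 2 (beyond the scatter), this leaves compound 1 the highest of the three, since the one exchange tried at each of these two places lowers the number. No available data account for the fall on going from methoxy to isopropoxy.

The compounds shown leave open whether a different group on this oxygen, such as ethyl, cyclopropyl or a longer chain ending in an amine, would keep or raise the number. Also open, from the compounds shown here alone, is how isopropoxy behaves with 3-methyl-1,2-oxazol-5-yl on the shared core.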